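The source may hold more compounds than are shown below. What is called first, only, known or untested is meant among the compounds shown, and "the series" means these compounds.

Compound 1 `COc1ccc(-c2cc(/C=C/C(=O)c3ccc(N)cc3)[nH]n2)cc1` is a small set's starting point: in a functional assay on SW-620 cells (Homo sapiens) for cytotoxicity, read by sulforhodamine B assay, with a stated time of 48 h, tested at 10 uM (on this read-out lower numbers stand for a stronger effect and higher numbers for a weaker effect at the one concentration tested), compound 1 gives -26%. Compound 2 `COc1cc(-c2cc(/C=C/C(=O)c3ccc(N)cc3)[nH]n2)cc(OC)c1OC`, which carries three methoxy groups, gives -20% in this assay; compound 2 and compound 1 lie within the scatter of each other, so the two numbers cannot be told apart. Compound 3 `COc1ccc(-c2cc(/C=C/C(=O)c3ccc(N)cc3)[nH]n2)cc1OC` differs from compound 2 by hydrogen in place of methoxy on an aromatic carbon. Because compound 1 gives -26% and compound 2 gives -20%, no step beyond the scatter is expected here. The step from compound 2 to compound 3 is estimated as a number 2 percentage points lower from compound 2 to compound 3 (within the scatter). Compound 3 is expected to give about -22%, in a range from -40% to -5%.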

Compound 3, a percentage reported as activity, at one concentration (the size of the read-out at that concentration, not a potency): -18%
For compound 3 the middle estimate is 4 percentage points below the measured one, within the range that was stated.
By their numbers in this assay, from the lowest: compounds 1, 2 and 3 (each within the scatter of the next).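

In this assay, hydrogen in place of methoxy gives one step (a number 2 percentage points higher from compound 2 to compound 3 (within the scatter)), and methoxy in place of hydrogen at another ring carbon gives a second (a number 8 percentage points higher from compound 1 to compound 3 (within the scatter)). Compound 3 thus links the other two compounds by single changes, and at neither place can methoxy and hydrogen be told apart on this read-out. No measurement at hand offers an explanation for this result. Still open, going by these compounds, is whether an amine or a longer chain such as ethoxy on these aromatic carbons would give a step beyond the scatter.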